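Hydrazide series on A549: from compound 1 to compound 4

The source may report more compounds than this note shows. Statements on the series, on what has been measured and on what is new or still open speak of the compounds shown alone.

Measured compounds:
compound 1 `Cc1cccc(NNC(=O)c2ccc(NS(=O)(=O)c3cnc(O)nc3O)cc2)c1`: > 20000 nM (a limit)
compound 2 `Cc1ccccc1NNC(=O)c1cccc(NS(=O)(=O)c2cnc(O)nc2O)c1`: 14200 nM
compound 3 `O=C(NNc1cccc(Cl)c1)c1cccc(NS(=O)(=O)c2cnc(O)nc2O)c1`: 6640 nM

In a functional assay on A549 cells (Homo sapiens) for antiproliferative activity, read by MTT assay, with a stated time of 24 h (on this read-out lower numbers stand for stronger inhibition and higher numbers for weaker inhibition), compound 1 gives only a limit, > 20000 nM, so its position among the numbers shown is undetermined; it sits at the limit (the limit of > 20000 nM in this assay, at which 1 of the 3 values shown sits). Compound 4 `O=C(NNC(=O)c1cccc(Cl)c1)c1ccc(NS(=O)(=O)c2cnc(O)nc2O)cc1` is not yet measured. It differs from compound 1 by (3-chlorophenyl)carbonyl in place of 3-methylphenyl on an amine nitrogen. Among the compounds with values here, the one measured step with a chloro-for-methyl exchange on the amine nitrogen, a 2.1-fold lower number from compound 2 to compound 3 (0.33 log units; beyond the scatter), was modest, but it concerned an aryl group, not a carbonyl-bearing one, and a different placement of the sulfonamide, so it bears only loosely here. A modest lowering is expected, an at least 1.4-fold lower number from compound 1 to compound 4 (0.15 log units; that floor lies within the scatter), with wide uncertainty. Compound 4 is estimated at 14000 nM in this assay, between 5000 nM and 50000 nM.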

Compound 4, half-maximal inhibitory concentration: 2290 nM
Estimate against measurement, compound 4: 6.1-fold (0.79 log units) above; the whole stated range lies above it.
By their numbers in this assay, from the lowest: compound 4; then compound 3; then compound 2. At a limit, above all of these: compound 1.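

Within the data shown here, at this amine nitrogen, (3-chlorophenyl)carbonyl in place of 3-methylphenyl gives in this assay an at least 8.7-fold lower number from compound 1 to compound 4 (0.94 log units; beyond the scatter), so a carbonyl-bearing group is accepted here, whereas the only earlier step, among aryl groups alone, was a 2.1-fold lower number from compound 2 to compound 3 (0.33 log units; beyond the scatter). That size is only a floor, since compound 1 is a limit: the limit of > 20000 nM in this assay, at which 1 of the 4 values shown sits.

The change brings in the carbonyl and the chlorine together, so the data credit neither alone. From the compounds shown here alone, whether a (3-methylphenyl)carbonyl or an acetyl group on the same nitrogen would do as much stays open.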